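This account rests on a few compounds, and the source may have more. Where it says the series, first, only, none or still open, it means among the compounds named here.

Of the compounds shown here, three have been measured in an ADME assay on the whole organism for cytotoxicity, with Artemia salina as the target, with a stated time of 24 h; a higher number here means that more compound is needed for the effect, a lower number that less compound is needed. Compound 1 `COc1ccc(/C=C/C(=O)c2ccccc2NC(=O)NS(=O)(=O)c2ccc(C)cc2)cc1OC` gives 12.9 ug/mL. Compound 2 `CCc1cc(/C=C/C(=O)c2ccccc2NC(=O)NS(=O)(=O)c2ccc(C)cc2)cc(OC)c1OC` gives 19.2 ug/mL, and compound 3 `COc1cc(/C=C/C(=O)c2ccccc2NC(=O)NS(=O)(=O)c2ccc(C)cc2)ccc1O` gives 17.8 ug/mL. Compound 3 thus holds the second highest of the three numbers, yet the step of a 1.1-fold lower number from compound 2 to compound 3 (0.03 log units; within the scatter) and the step of a 1.4-fold higher number from compound 1 to compound 3 (0.14 log units; within the scatter) both stay within the scatter, so the three numbers cannot be ordered with confidence. The remaining step, a 1.5-fold higher number from compound 1 to compound 2 (0.17 log units; within the scatter), is within the scatter as well.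

Compound 4 `Cc1ccc(S(=O)(=O)NC(=O)Nc2ccccc2C(=O)/C=C/c2ccc(Cl)cc2)cc1` has not yet been measured. It differs from compound 3 by 4-chlorophenyl in place of 4-hydroxy-3-methoxyphenyl on a double-bonded chain carbon bound to a double-bonded chain carbon. The measured steps that bear on this change all touch the ring that is exchanged: a 1.1-fold lower number from compound 2 to compound 3 (0.03 log units; within the scatter) swaps the whole ring, a 1.4-fold higher number from compound 1 to compound 3 (0.14 log units; within the scatter) puts hydrogen in place of methyl on an oxygen on that ring, and a 1.5-fold higher number from compound 1 to compound 2 (0.17 log units; within the scatter) adds ethyl to it; none of them moves beyond the scatter. Among the compounds with values here, no measured step removes the hydrogen-bond donor and both acceptors of that ring or brings in chlorine, so the expectation rests only on the flat picture seen so far. In this assay the step of a 1.1-fold lower number from compound 3 to compound 4 (0.05 log units; within the scatter) is therefore expected to stay within the scatter, in no set direction. Compound 4 is estimated at 16 ug/mL, with a range from 8 ug/mL to 35 ug/mL.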

Compound 4, concentration for half-maximal effect: 6.92 ug/mL
For compound 4 the middle estimate is 2.3-fold (0.36 log units) above the measured one; measured number outside the range, below it.
By their numbers in this assay, from the lowest: compounds 4, 1, 3 and 2 (each within the scatter of the next, the first and the last beyond it).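

In this assay, within the data shown here, the exchange on a double-bonded chain carbon bound to a double-bonded chain carbon now gives steps beyond the scatter, which no step among the earlier compounds did: a 2.6-fold lower number from compound 3 to compound 4 (0.41 log units; beyond the scatter) with 4-chlorophenyl in place of 4-hydroxy-3-methoxyphenyl, and a 2.8-fold lower number from compound 2 to compound 4 (0.44 log units; beyond the scatter) with 4-chlorophenyl in place of 3-ethyl-4,5-dimethoxyphenyl. Compound 1 goes against a clean split between 4-chlorophenyl and the oxygen-bearing rings, since a 1.9-fold lower number from compound 1 to compound 4 (0.27 log units; within the scatter) with 4-chlorophenyl in place of 3,4-dimethoxyphenyl, so compound 4 cannot be ranked apart from all the others. Nothing in hand accounts for this result.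

The exchange brings in chlorine and removes the ring's oxygen substituents in a single step, so the compounds shown do not separate the contribution of the chlorine from that of the lost groups. On these data alone, whether plain phenyl, or a ring carrying bromine, trifluoromethyl, an amine or a carboxylic acid, would sit with compound 4 or with compound 2 remains open, as does whether the step holds when the shared core is changed elsewhere.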